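Swapping a Methoxyphenyl for a Trimethylpyrazole on the Amide

The source may hold more compounds than are shown below. What is called first, only, known or untested is meant among the compounds shown, and "the series" means these compounds.

compound 1, `COc1cccc(C(C)NC(=O)COc2cc(C(F)(F)F)c3c(-c4ccccc4)nn(C)c3n2)c1`: 26 nM
compound 2, `C[C@H](NC(=O)CNc1cc(C(F)(F)F)c2c(-c3ccccc3)nn(C)c2n1)c1ccccc1`: 1140 nM

Of the compounds shown here, two built on the same core have been measured in a functional assay on isolated protein for antagonist activity at Orexin receptor type 2 (Homo sapiens), read by fluorescence, FLIPR and calcium flux, with a stated time of 1 h; on this read-out lower numbers stand for stronger inhibition and higher numbers for weaker inhibition. Compound 1 gives 26 nM, the lower of the two numbers. Compound 2 gives 1140 nM, a much higher number and well beyond the scatter. Compound 2 differs from compound 1 in more than one place, an amino link in place of the ether and a plain phenyl with a defined stereocentre, so these two values cannot be tied to any single change.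

Compound 3, `Cc1nn(C)c(C)c1[C@H](C)NC(=O)COc1cc(C(F)(F)F)c2c(-c3ccccc3)nn(C)c2n1`, keeps the ether link and the core of compound 1 and alters only the group on the amide nitrogen: 1-(1,3,5-trimethyl-1H-pyrazol-4-yl)ethyl in place of 1-(3-methoxyphenyl)ethyl on an amide-type nitrogen. Going by the values given here, no measured pair shows this exact exchange, so the expectation rests on compound 1 alone. A five-membered ring carrying three methyl groups and two acceptors replaces a six-membered ring with one acceptor; such a change is expected to shift the number only modestly, probably upward, and perhaps not beyond the scatter. Compound 3 is therefore estimated at 60 nM, within 15 nM to 300 nM, which would mean an expected step of a 2.3-fold higher number from compound 1 to compound 3 (0.36 log units; beyond the scatter).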

Compound 3, inhibition constant: 10 nM
For compound 3 the middle estimate is 6.0-fold (0.78 log units) above the measured one; measured number below the stated range.
By their numbers in this assay, from the lowest: compound 3; then compound 1; then compound 2.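

Exchanging 1-(3-methoxyphenyl)ethyl for 1-(1,3,5-trimethyl-1H-pyrazol-4-yl)ethyl on the amide-type nitrogen gives a 2.6-fold lower number from compound 1 to compound 3 (0.41 log units; beyond the scatter) in this assay. Going by these compounds alone, this is the first change in a single place in this set, and it shows that the six-membered aromatic ring of carbon only is not required here: a five-membered aromatic ring with 2 hetero atoms serves at least as well, with both groups counting 10 heavy atoms. No measurement on hand explains why the number falls.

The entering group also carries a defined stereocentre, while none is recorded for the group that leaves, so the shown compounds cannot separate the effect of the ring exchange from that of the stereocentre. Going by these compounds, it also remains open whether the three methyl groups matter, which a 1-(1H-pyrazol-4-yl)ethyl group on the same nitrogen would test, and whether the gain carries over to the amino-linked series of compound 2.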